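The compounds below may be only part of what the source reports. "The series", "measured", "known", "first", "only" and "open" are said of these compounds alone.

Compound 1 `O=S(=O)(Nc1ccc(-c2nc3ccccc3o2)cc1)c1ccccc1O` is one of three compounds examined in an assay on isolated protein for inhibition of malate dehydrogenase, mitochondrial (Sus scrofa), with stated times of 45 min and 30 min; a lower number here means a stronger inhibitor, a higher number a weaker inhibitor. In this assay compound 1 gives only a limit, > 63000 nM. Compound 2 `O=S(=O)(Nc1ccc2oc(-c3ccccc3)nc2c1)c1ccccc1C(F)(F)F` likewise reaches only a limit in this assay, > 63000 nM. Compound 3 `O=S(=O)(Nc1ccc2oc(-c3ccccc3)nc2c1)c1cccc(C(F)(F)F)c1` also stops at a limit in this assay, > 63000 nM. All three thus sit at the same point: the limit of > 63000 nM in this assay, at which 3 of the 3 values shown sit. No step between two measured compounds can be counted, so compound 1 stands at the limit alongside the other two, and the numbers shown place it neither above nor below them.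

Compound 4 `O=S(=O)(Nc1ccc(-c2nc3ccccc3o2)cc1)c1ccc(F)cc1` differs from compound 1 by 4-fluorophenyl in place of 2-hydroxyphenyl on a sulfonyl sulfur. Nothing among the three measured compounds shows a change of this kind moving the read-out off the limit in this assay. The step that the limit leaves unreadable from compound 1 to compound 4 is therefore expected to be none beyond the scatter, with compound 4 most likely resting at the limit as well. Compound 4 is expected to give 100000 nM in this assay, within a range from 30000 nM to 300000 nM.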

Compound 4, half-maximal inhibitory concentration: > 63000 nM
Compound 4: no number, only a limit; the forecaster's own chance of this, stated with the estimate: 80%; the middle value lies beyond the limit too.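

Compound 4 also stops at a limit, so no step from compound 1 to compound 4 can be read in this assay: the limit of > 63000 nM in this assay, at which 4 of the 4 values shown sit.

The compounds shown leave open whether any change to these structures would yield a number rather than a limit in this assay.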